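A few compounds are considered here, and "the series" means these few. Any claim that something is new, unique, unknown or untested is made for them only; others in the source may bear on it.

Measured so far:
compound 1 `CC(C)CC1(O)CCN(C(=O)Nc2cc(Oc3ccc(C(=O)O)cc3)cc(Oc3ccc(F)c(F)c3)c2)CC1` gives 22.2 nM in an ADME assay on the whole organism for pharmacokinetics, with Rattus norvegicus as the target, at a dose of 1 mg/kg by the oral route; a lower number here means less compound in the circulation, a higher number more compound in the circulation at the dose given;
compound 2 `CC(C)CC1(O)CCN(C(=O)Nc2cc(Oc3ccc(F)cc3)cc(Oc3ccc(C(=O)O)cc3F)c2)CC1` gives 27.8 nM in this assay.

Compound 2 has the higher of the two numbers, but its number and that of compound 1 sit close enough that the gap falls within the usual scatter of repeated measurements, so the two cannot be told apart. Among the compounds with values here, the two structures also differ in more than one place, so no single step connects them.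

Compound 3 `CC(C)CC1(O)CCN(C(=O)Nc2cc(Oc3ccc(F)cc3)cc(Oc3ccc(C(=O)O)cc3)c2)CC1` differs from compound 2 in one place: hydrogen in place of fluoro on an aromatic carbon. Within the data shown here, no measured pair shows this change on its own. Compound 1, which also carries no fluoro on its carboxyphenyl ring, gives 22.2 nM, a number within the scatter of compound 2. The step from a 1.2-fold lower number from compound 2 to compound 3 (0.06 log units; within the scatter) is therefore expected to be none beyond the scatter. Compound 3 is estimated at 24 nM, with a likely range from 10 nM to 55 nM.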

Compound 3, maximal plasma concentration: 34.5 nM
The estimate for compound 3 lay 1.4-fold (0.16 log units) below the measured number; the measured number falls inside the stated range.
By their numbers in this assay, from the lowest: compounds 1, 2 and 3 (each within the scatter of the next).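

Hydrogen in place of the fluoro of the 4-carboxy-2-fluorophenyl group, on an aromatic carbon ortho to a large group and meta to a carboxy group, leaves the number in this assay within the scatter (a 1.2-fold higher number from compound 2 to compound 3 (0.09 log units; within the scatter)). The same kind of change at a different aromatic carbon, on the ring without the carboxy group, also stays within the scatter (a 1.6-fold higher number from compound 1 to compound 3 (0.19 log units; within the scatter)), so neither fluoro makes a readable difference to this read-out. Nothing measured here bears on why these numbers sit so close together.

Going by these compounds, whether a larger group at the first of these carbons, such as methoxy or an amine, would move the number beyond the scatter remains open. All the compounds shown also keep the carboxy group, so the effect of replacing it with a nitrile or a tetrazole on this read-out is equally unknown.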